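Aniline swap on the shared core: outlook for compound 3

A few compounds are considered here, and "the series" means these few. Any claim that something is new, unique, unknown or untested is made for them only; others in the source may bear on it.

Compound 1 `CCS(=O)(=O)Nc1cc(-c2ccc3ncnc(Nc4ccc(F)cc4)c3c2)cnc1OC` and compound 2 `CCS(=O)(=O)Nc1cc(-c2ccc3ncnc(Nc4ccc(F)cc4F)c3c2)cnc1OC` share one core and differ only in the aryl group on the ring nitrogen. In a functional assay on A549 cells (Homo sapiens) for cytotoxicity, read by sulforhodamine B assay, with a stated time of 72 h (on this read-out higher numbers stand for weaker inhibition and lower numbers for stronger inhibition), compound 1 gives 7620 nM, and in this assay compound 2 gives 4710 nM. The step of a 1.6-fold lower number from compound 1 to compound 2 (0.21 log units; within the scatter) comes from fluoro in place of hydrogen on an aromatic carbon. Compound 2 holds the lower of the two numbers shown in this assay, but its gap to compound 1 lies within the scatter, so no ordering can be read from the pair.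

Compound 3 `CCS(=O)(=O)Nc1cc(-c2ccc3ncnc(Nc4ccc(OC(F)(F)F)cc4)c3c2)cnc1OC` is not yet measured. Its difference from compound 2 is 4-(trifluoromethoxy)phenyl in place of 2,4-difluorophenyl on a nitrogen on an aromatic ring. Within the data shown here, the only measured step, from compound 1 to compound 2, changes the same aryl group by a single fluoro and stayed within the scatter; no measured step replaces the whole aryl, so that step bears on the present change only loosely. With nothing pointing to a shift beyond the scatter, the step expected in this assay is a 1.3-fold higher number from compound 2 to compound 3 (0.11 log units; within the scatter), with wide uncertainty. Compound 3 is therefore estimated at 6000 nM in this assay, within a range of 2000 nM to 20000 nM.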

Compound 3, half-maximal inhibitory concentration: 25400 nM
Beside the measured number, compound 3's estimate is 4.2-fold (0.63 log units) below it; measured number above the stated range.
By their numbers in this assay, from the lowest: compounds 2 and 1 (each within the scatter of the next); then compound 3.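

In this assay, among these compounds, the aryl group on the ring nitrogen now moves the number beyond the scatter, which the single fluoro change did not do: replacing 2,4-difluorophenyl with 4-(trifluoromethoxy)phenyl gives a 5.4-fold higher number from compound 2 to compound 3 (0.73 log units; beyond the scatter). The narrower change, trifluoromethoxy in place of fluoro on an aromatic carbon, points the same way with a 3.3-fold higher number from compound 1 to compound 3 (0.52 log units; beyond the scatter), so compound 3 is the weakest of the three, with both of its steps beyond the scatter, and this site on the series is not indifferent to the aryl substituent. No supporting data on the compounds accompany these numbers, so the shift stands as an observation with no explanation attached.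

The compounds shown do not separate the contribution of the oxygen link from that of the three fluorines, a question that a methoxy or a trifluoromethyl group in place of the trifluoromethoxy group on the same phenyl would address. They also leave open whether any aryl group on this nitrogen can take the number clearly lower than compound 2, for instance a phenyl carrying a chloro, a nitrile or an amine.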